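Methylamino for cyclopropyl on the shared core

The source may hold more compounds than are shown below. What is called first, only, known or untested is meant among the compounds shown, and "the series" means these compounds.

Compound 1 `Cc1ncncc1-c1nc2cc(F)c(F)cc2n1C1CC1` bears a methyl on an aromatic carbon of its six-membered ring with 2 nitrogen, and in an ADME assay on cells for inhibition of cytochrome P450 11B1, mitochondrial (Homo sapiens), read by HPLC, with a stated time of 60 min (on this read-out lower numbers stand for stronger inhibition and higher numbers for weaker inhibition), compound 1 gives 4160 nM. Compound 2 `Fc1cc2nc(-c3cncnc3C3CC3)n(C3CC3)c2cc1F` carries a cyclopropyl in that place. In this assay compound 2 gives only > 10000 nM, a limit of the assay rather than a number. Going by the values given here, the single measured step, an at least 2.4-fold higher number from compound 1 to compound 2 (0.38 log units; beyond the scatter), is therefore a weakening whose full size is unknown because of the limit of > 10000 nM in this assay, at which 1 of the 2 values shown sits; compound 2 stands at the weak end of the two values shown.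

Compound 3 `CNc1ncncc1-c1nc2cc(F)c(F)cc2n1C1CC1` is the next step: methylamino in place of cyclopropyl on an aromatic carbon. Among the compounds with values here, the only step that bears on it is the one from methyl to cyclopropyl, which was at least modest in the weakening direction; methylamino, with its 2 heavy atoms and no ring, returns the site to a smaller group, closer in size to methyl. A lower number than the limit of compound 2 is therefore expected, roughly back toward the level of compound 1, with a fair chance that only a limit is reported again. Compound 3 is estimated at 5000 nM in this assay, within 1500 nM to 20000 nM. The expected step is an at least 2.0-fold lower number from compound 2 to compound 3 (0.30 log units; that floor lies within the scatter).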

Compound 3, half-maximal inhibitory concentration: 390 nM
Beside the measured number, compound 3's estimate is 13-fold (1.11 log units) above it; the whole stated range lies above it.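

In this assay, this position proves to be more than a site where a smaller group is merely tolerated: methylamino gives an 11-fold lower number from compound 1 to compound 3 (1.03 log units; beyond the scatter) and so goes well past methyl, which was the better of the two groups seen before. Against cyclopropyl, the same group gives an at least 25-fold lower number from compound 2 to compound 3 (1.40 log units; beyond the scatter) on the aromatic carbon next to the ring nitrogen, so the order at this place is not read from heavy-atom count alone, and the change that stands out is the entry of methylamino with its hydrogen-bond donor and acceptor. Going by these compounds, compound 2 sits at a limit of the assay, and that step is a floor whose full size stays unknown because of the limit: the limit of > 10000 nM in this assay, at which 1 of the 3 values shown sits.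

Which feature of methylamino carries the gain stays open, and amino, dimethylamino, ethylamino or methoxy at this place would bear on whether the nitrogen, its hydrogen or the chain length counts. On these data alone, whether the same gain appears with other groups on the rest of the shared core also remains open.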